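The compounds below may be only part of what the source reports. "The series", "measured", "known", "first", "only" and "open" are said of these compounds alone.

Measured so far:
- compound 1, `CCCCC(=O)OCc1ccc2oc(=O)c(C(=O)Oc3cccc(Br)c3)cc2c1`, in a functional assay on HT-1080 cells (Homo sapiens), read by transwell migration, with a stated time of 24 h, tested at 1 uM (on this read-out higher numbers stand for a weaker effect at the one concentration tested and lower numbers for a stronger effect), compound 1 gives 63.3%
- compound 2, `CCCCCC(=O)OCc1ccc2oc(=O)c(C(=O)Oc3cccc(Br)c3)cc2c1`, in this assay compound 2 gives 59.3%

On these two numbers compound 2 stands lowest, with compound 1 nearest at a number 4 percentage points lower from compound 1 to compound 2 (within the scatter), a gap within the scatter. Compound 3, `CC(C)C(=O)OCc1ccc2oc(=O)c(C(=O)Oc3cccc(Br)c3)cc2c1`, differs from compound 2 by isopropyl in place of pentyl on a carbonyl carbon. Among the measured compounds shown here, the only step bearing on this change is the chain-lengthening step from compound 1 to compound 2, which read a number 4 percentage points lower from compound 1 to compound 2 (within the scatter). That step stayed within the scatter, so no shift beyond the scatter is expected for compound 3 either, with a number 4.7 percentage points higher from compound 2 to compound 3 (within the scatter) as the expected step. The estimate for compound 3 in this assay is 64%, with a range from 52% to 76%.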

Compound 3, a percentage reported as activity, at one concentration (the size of the read-out at that concentration, not a potency): 37.8%
Beside the measured number, compound 3's estimate is 26.2 percentage points above it; measured number below the stated range.
By their numbers in this assay, from the lowest: compound 3; then compounds 2 and 1 (each within the scatter of the next).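

At the carbonyl carbon whose other neighbours are oxygen next to a carbonyl group, the earlier butyl and pentyl pair gave no separation, but isopropyl separates from both in this assay. The readings are (a number 21.5 percentage points lower from compound 2 to compound 3 (beyond the scatter)) and (a number 25.5 percentage points lower from compound 1 to compound 3 (beyond the scatter)), so the group at this place can move the read-out beyond the scatter. Nothing measured here gives a reason for this step.

Isopropyl differs from both straight chains in size and in branching, so the two compounds' steps do not separate these features. A straight propyl chain, a tert-butyl group or a cyclopropyl ring at this place would bear on that question.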